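The compounds below may be only part of what the source reports. "The series", "measured", "known", "first", "only" and "open" are said of these compounds alone.

Of the compounds shown here, three sharing one core have been tested in a functional assay on NCI-H460 cells (Homo sapiens) for cytotoxicity, read by MTT assay, with a stated time of 72 h; on this read-out higher numbers stand for weaker inhibition and lower numbers for stronger inhibition. Compound 1 `COc1cc2c(Oc3ccc(NC(=O)c4nnn(-c5ccc(C)cc5)c4C(F)(F)F)cc3F)ccnc2cc1OCCCN1CCC(C)CC1` gives 1250 nM and stands with the highest number of the three. Compound 2 `COc1cc2c(Oc3ccc(NC(=O)c4nnn(-c5ccccc5C(F)(F)F)c4C(F)(F)F)cc3F)ccnc2cc1OCCCN1CCC(C)CC1` gives 250 nM, and compound 3 `COc1cc2c(Oc3ccc(NC(=O)c4nnn(-c5ccc(F)c(F)c5)c4C(F)(F)F)cc3F)ccnc2cc1OCCCN1CCC(C)CC1` gives 230 nM. The two measured changes both alter the aryl group on the aromatic nitrogen of the core: a 5.0-fold lower number from compound 1 to compound 2 (0.70 log units; beyond the scatter) and a 5.4-fold lower number from compound 1 to compound 3 (0.74 log units; beyond the scatter), while a 1.1-fold lower number from compound 2 to compound 3 (0.04 log units; within the scatter).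

Compound 4 `COc1cc2c(Oc3ccc(NC(=O)c4nnn(-c5ccc(C)cc5)c4C(F)(F)F)cc3F)ccnc2cc1OCCCN1CCN(C)CC1` differs from compound 1 at a different place altogether: 4-methylpiperazin-1-yl in place of 4-methylpiperidin-1-yl on a saturated chain carbon, three bonds along the chain from an oxygen on an aromatic ring. Going by the values given here, none of the measured steps touches this chain end, so they give no direct guide to the size or direction of this change; the aryl group on the aromatic nitrogen, which drove the measured steps, is the same in compound 1 and compound 4. With nothing to indicate a shift, the expectation for compound 4 in this assay is a number close to that of compound 1, a step of no change at the digits printed from compound 1 to compound 4 (within the scatter) that is not expected to go beyond the scatter. Compound 4 is therefore estimated at 1250 nM, with a likely range from 400 nM to 4000 nM.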

Compound 4, half-maximal inhibitory concentration: 1240 nM
Compound 4: middle estimate off by 1.0-fold (0.00 log units), on the high side, and the stated range covers the measured number.
By their numbers in this assay, from the lowest: compounds 3 and 2 (each within the scatter of the next); then compounds 4 and 1 (each within the scatter of the next).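

In this assay, exchanging 4-methylpiperidin-1-yl for 4-methylpiperazin-1-yl gives a 1.0-fold lower number from compound 1 to compound 4 (0.00 log units; within the scatter), so the two compounds cannot be told apart on this read-out. Going by these compounds alone, this is the first reading at the end of the chain: the earlier steps all changed the aryl group on the aromatic nitrogen, and one of them gave a 5.0-fold lower number from compound 1 to compound 2 (0.70 log units; beyond the scatter), so in this pair, with 4-methylphenyl on that nitrogen, a second ring nitrogen at the chain end leaves the number within the scatter, unlike that aryl exchange. No supporting data are available to explain this outcome.

On these data alone, this single pair carries 4-methylphenyl on the aromatic nitrogen, so it remains open whether the same exchange would also stay within the scatter with the 3,4-difluorophenyl group of compound 3 or the 2-(trifluoromethyl)phenyl group of compound 2. As far as these compounds go, it also remains open how a morpholin-4-yl ring, an open dimethylamino group or a longer chain in place of the propyl link would read in this assay.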